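Adding an Acetoxyphenyl Cap to a Weak Antiproliferative

A few compounds are considered here, and "the series" means these few. Any claim that something is new, unique, unknown or untested is made for them only; others in the source may bear on it.

Among the measured compounds shown here, compound 2 `O=C1NC(=S)S/C1=C\N1N=C(c2ccc(Cl)cc2)CC1c1ccc(Cl)cc1` is the only compound here with an actual number: in a functional assay on SK-OV-3 cells (Homo sapiens) for antiproliferative activity, read by MTT assay, with a stated time of 72 h (a lower number here means a stronger inhibitor, a higher number a weaker inhibitor), compound 2 gives 9140 nM. Compound 1 `CC(=O)Oc1cccc(N2C(=O)/C(=C/N3N=C(c4ccccc4)CC3c3ccc(N(C)C)cc3)SC2=S)c1` gives > 10000 nM in this assay, which is a limit and not a number. Compound 3 `CC(=O)Oc1ccc(N2C(=O)/C(=C/N3N=C(c4ccc(Cl)cc4)CC3c3ccc(Cl)cc3)SC2=S)cc1` differs from compound 2 by 4-acetoxyphenyl in place of hydrogen on an amide-type nitrogen in a ring. For the measured compounds named here, no step between measured compounds is available to guide this change, so no shift beyond the usual scatter is expected; the step is estimated as a 1.3-fold higher number from compound 2 to compound 3 (0.12 log units; within the scatter). Compound 3 is expected near 12000 nM, with a range from 4000 nM to 40000 nM.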

Compound 3, half-maximal inhibitory concentration: > 10000 nM
Compound 3: no number, only a limit; the forecaster's own chance of this, stated with the estimate: 55%; the middle value does not contradict the limit.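

In this assay the 4-acetoxyphenyl group on the amide-type nitrogen gives an at least 1.0-fold higher number from compound 2 to compound 3 (0.03 log units; that floor lies within the scatter) as the first step read at this position. Compound 3 has a limit and not a number, so this step has only a floor, and its true size cannot be read because the readings stop at a ceiling: the limit of > 10000 nM in this assay, at which 2 of the 3 values shown sit.

Still open, on these data alone, is how a smaller group on this nitrogen, such as methyl or plain phenyl, would read. Also open, as far as these compounds go, is whether a phenyl bearing a free hydroxyl or an amine would give a measurable number.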